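The source may report more compounds than this note shows. Statements on the series, on what has been measured and on what is new or still open speak of the compounds shown alone.

Measured so far in a functional assay on HEK293 cells for agonist activity at Bombesin receptor subtype-3 (Mus musculus), read by luminescence and calcium flux, with a stated time of 10 min; a lower number here means that less compound is needed, a higher number that more compound is needed for the effect:
compound 1 `CCC(C)(C)Cc1c[nH]c(CCc2ccc(-c3ccncc3)cc2)n1` gives 103 nM
compound 2 `CCC(C)(C)Cc1c[nH]c(CCc2ccc(-n3ncnn3)cc2)n1` gives 99 nM
compound 3 `CCC(C)(C)Cc1c[nH]c(CCc2ccc(-c3cccc(N)n3)cc2)n1` gives 119 nM

Compound 2 has the lowest of the three numbers, but its two neighbours stand so close that no order can be read from them: the steps of a 1.0-fold lower number from compound 1 to compound 2 (0.02 log units; within the scatter) and a 1.2-fold higher number from compound 2 to compound 3 (0.08 log units; within the scatter) both stay within the scatter, as does a 1.2-fold higher number from compound 1 to compound 3 (0.06 log units; within the scatter). The three compounds share one core and differ only in the ring attached on an aromatic carbon at the far end of the molecule, and swapping that ring among pyridin-4-yl, 2H-tetrazol-2-yl and 6-aminopyridin-2-yl left this assay essentially unchanged.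

Compound 4 `CCC(C)(C)Cc1c[nH]c(CCc2ccc(-c3ccns3)cc2)n1` has not yet been measured. It differs from compound 2 in exactly that place: 1,2-thiazol-5-yl in place of 2H-tetrazol-2-yl on an aromatic carbon. Every measured step bears on this change, since each one exchanged a small aromatic ring at the same aromatic carbon for another, and none of them moved the number beyond the scatter. The same is therefore expected of compound 4 in this assay: a step of a 1.1-fold higher number from compound 2 to compound 4 (0.03 log units; within the scatter), which is no step beyond the scatter in either direction. Compound 4 is thus estimated at 105 nM, with a likely range from 45 nM to 250 nM.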

Compound 4, half-maximal effective concentration: 103 nM
Estimate against measurement, compound 4: 1.0-fold (0.01 log units) above, within the range that was stated.
By their numbers in this assay, from the lowest: compounds 2, 1, 4 and 3 (each within the scatter of the next).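

For the compounds shown here, the new ring brings sulfur to this position for the first time: 1,2-thiazol-5-yl has 3 carbon, 1 nitrogen and 1 sulfur among its 5 heavy atoms, where 2H-tetrazol-2-yl has 1 carbon and 4 nitrogen, and it has 2 hydrogen-bond acceptors instead of 4. Even so, this assay records only a 1.0-fold higher number from compound 2 to compound 4 (0.02 log units; within the scatter) for this exchange, so a clear difference in ring make-up comes with no readable shift in the number. The comparisons with the other two rings agree, with a 1.2-fold lower number from compound 3 to compound 4 (0.06 log units; within the scatter) and with no change at the digits printed from compound 1 to compound 4 (within the scatter), so the four compounds form one group without an order, and none of them goes against this.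

Going by these compounds, all four groups at this aromatic carbon are small aromatic rings, so it remains open whether a carboxylic acid, an amine, a longer alkyl chain or a plain hydrogen there would leave the number just as flat. Nothing available here explains why these different rings give such closely matching numbers.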